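A few compounds are considered here, and "the series" means these few. Any claim that something is new, unique, unknown or untested is made for them only; others in the source may bear on it.

Working notes on the series. Of the compounds shown here, three have been read in a functional assay on PC-3 cells (Homo sapiens) for antiproliferative activity, read by MTT assay, tested at 5 uM; on this read-out lower numbers stand for a weaker effect and higher numbers for a stronger effect at the one concentration tested. Compound 1 `COc1ccc(/C=N/NC(=O)c2cc(OC)c(OC)c(OC)c2)c(OC)c1` gives 22.2% in this assay. Compound 2 `COc1cc(C2=NN(C(C)=O)C(c3cccc(OC)c3OC)O2)cc(OC)c1OC` gives 58.2%. Compound 3 `COc1cc(C(=O)N/N=C/c2cccc(C(F)(F)F)c2)cc(OC)c1OC` gives 79.8%. On these three numbers compound 2 stands second highest: its nearest neighbour is compound 3, a number higher by a margin beyond the usual scatter, and the furthest is compound 1, a number lower by a margin also beyond the scatter. No pair of these compounds differs in one place only, so no single step between measured compounds is available.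

The next compound, compound 4 `COc1cc(C2=NN(C(C)=O)C(c3ccc(Cl)c(Cl)c3)O2)cc(OC)c1OC`, differs from compound 2 in one place: 3,4-dichlorophenyl in place of 2,3-dimethoxyphenyl on a saturated ring carbon. No change of this kind has been measured on this core, so the size of the step in this assay is open. The two measured compounds that carry a halogen-bearing or unsubstituted aryl beside the shared core are not comparable one to one, and nothing in the data fixes a direction. The expectation is a step of at most modest size, within or just beyond the scatter, slightly upward, for compound 4 a number 3.8 percentage points higher from compound 2 to compound 4 (within the scatter). Compound 4 is therefore estimated at 62% in this assay, with a range from 40% to 80%.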

Compound 4, a percentage reported as inhibition, at one concentration (the size of the read-out at that concentration, not a potency): 26.1%
Beside the measured number, compound 4's estimate is 35.9 percentage points above it; the whole stated range lies above it.
By their numbers in this assay, from the lowest: compounds 1 and 4 (each within the scatter of the next); then compound 2; then compound 3.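

In this assay, within the data shown here, the first single-place step is large: 3,4-dichlorophenyl in place of 2,3-dimethoxyphenyl on the saturated ring carbon gives a number 32.1 percentage points lower from compound 2 to compound 4 (beyond the scatter). The aryl group at this position of the shared core is therefore not a silent part of the structure, and the read-out at the one concentration tested depends on what this group carries. The step exchanges a group with 2 hydrogen-bond acceptors for one with 0 and also alters the substituents and their placement on the aryl ring, so this single pair cannot separate the loss of the two methoxy groups from the entry of the two chlorines, and no measurement at hand explains the size of the step.

The compounds shown leave open whether the read-out at this position would hold with an unsubstituted phenyl or a 3,4-dimethoxyphenyl, which would help separate substituent identity from substituent placement. They also leave open how an aryl group carrying a dimethylamino group or a carboxylic acid would read on this core.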